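The source may report more compounds than this note shows. Statements on the series, on what has been measured and on what is new or still open speak of the compounds shown alone.

Three compounds have been measured in a functional assay on LS174T cells (Homo sapiens) for inhibition, with a stated time of 4 days, tested at 1 uM; a higher number here means a stronger effect of the compound at the concentration tested, a lower number a weaker effect:

compound 1, `CN(C)c1cnc(C#Cc2c(F)cccc2F)cn1`, gives 22.9%
compound 2, `Fc1cccc(F)c1C#Cc1ccc2[nH]ncc2c1`, gives 17.6%
compound 3, `Fc1cccc(F)c1C#Cc1ccc2cn[nH]c2c1`, gives 81.5%

Compound 3 stands highest of the three numbers. Its nearest neighbour on the scale is compound 1, whose reading lies well beyond the usual scatter below it, and compound 2 lies further still. Compound 2 and compound 3 share the same fused two-ring core and the same difluorophenyl-ethynyl arm; the two values show that the inhibition reported for compound 3 is far larger than that reported for compound 2, and no more than that can be read from the pair.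

Compound 4, `Cn1ncc2ccc(C#Cc3c(F)cccc3F)cc21`, has not yet been measured in this assay. It differs from compound 3 in one place: methyl in place of hydrogen on an aromatic nitrogen. The hydrogen on the aromatic nitrogen of the five-membered ring is replaced by a methyl, next to the ring nitrogen.

Going by the values given here, no measured pair isolates this change, so the expectation rests on the spread of the three numbers alone. Compound 4 is expected to give a lower reading than compound 3, a step of a number 36.5 percentage points lower from compound 3 to compound 4 (beyond the scatter) that is estimated to lie beyond the scatter. For compound 4 the estimated value in this assay is 45%, with a range from 10% to 85%.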

Compound 4, a percentage reported as inhibition, at one concentration (the size of the read-out at that concentration, not a potency): 85.9%
Compound 4: the middle estimate sits 40.9 percentage points below what was measured; the measured number lies above the stated range.
By their numbers in this assay, from the lowest: compounds 2 and 1 (each within the scatter of the next); then compounds 3 and 4 (each within the scatter of the next).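

In this assay, methyl in place of hydrogen on an aromatic nitrogen of the five-membered aromatic ring amounts to a number 4.4 percentage points higher from compound 3 to compound 4 (within the scatter), so the two readings cannot be told apart. The earlier compounds shown here could not show this, as no measured pair among them isolated a single change: this pair shows that, at the concentration tested, the reading does not depend on a hydrogen at this nitrogen, and that one added carbon in the form of a methyl is tolerated here. Nothing at hand bears on why the reading is the same with either group on this nitrogen, and the result gives no cause.

The compounds shown leave open how far this tolerance extends, for instance whether an ethyl, a longer chain, a benzyl or a chain ending in an amine or a carboxylic acid on the same nitrogen would give a similar reading. They also leave open whether compound 3 and compound 4 would still match at other concentrations, as a reading at one concentration gives the size of the effect there and not a potency.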